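Carbonyl Substituent Change in a Weakly Active Pair

This account rests on a few compounds, and the source may have more. Where it says the series, first, only, none or still open, it means among the compounds named here.

Compound 1 `O=C(c1ccccc1)c1cc2cc(O)ccc2oc1=O` gives 51700 nM in an in vitro assay on BTI-TN-5B1-4 cells for inhibition of Amine oxidase [flavin-containing] A (Homo sapiens), read by fluorescence, with a stated time of 15 min; on this read-out higher numbers stand for weaker inhibition and lower numbers for stronger inhibition. Among the compounds with values here, only one other number is available: compound 2 `CCOC(=O)c1cc2ccc(OC3CCCCCC3)cc2oc1=O` gives 46400 nM in this assay, and the two values lie within the scatter of each other, so neither can be ranked. Compound 3 `O=C(O)c1cc2cc(O)ccc2oc1=O` differs from compound 1 by hydroxy in place of phenyl on a carbonyl carbon. Within the data shown here, no measured step of this kind exists, and both known values sit in the same weak range. For compound 3 a modest step is expected, possibly toward a weaker number, with an estimated step of a 1.5-fold higher number from compound 1 to compound 3 (0.19 log units; within the scatter). Compound 3 is estimated at 80000 nM, in the range 25000 nM to 250000 nM.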

Compound 3, half-maximal inhibitory concentration: 40200 nM
Compound 3: middle estimate off by 2.0-fold (0.30 log units), on the high side, within the range that was stated.
By their numbers in this assay, from the lowest: compounds 3, 2 and 1 (each within the scatter of the next).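

Within the data shown here, on the carbonyl carbon, hydroxy in place of phenyl gives a 1.3-fold lower number from compound 1 to compound 3 (0.11 log units; within the scatter) in this assay, the first measured step at this position. Removing the phenyl ring there therefore gives no readable difference, and compound 1 and compound 3 both sit in the same weak range. No available evidence bears on this result.

As far as these compounds go, whether an amide or an amine-bearing chain on this carbonyl carbon would give a step beyond the scatter remains open. Also open, from the compounds shown here alone, is whether any change at this position separates from these weak values.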